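Varying the Aryl Ketone Substituent in a Pyrazole Chalcone Series

This account rests on a few compounds, and the source may have more. Where it says the series, first, only, none or still open, it means among the compounds named here.

Measured so far:
compound 1 `COc1cc(-c2cc(/C=C/C(=O)c3ccc(Cl)c(Cl)c3)[nH]n2)cc(OC)c1OC` gives 95%
compound 2 `COc1ccc(C(=O)/C=C/c2cc(-c3cc(OC)c(OC)c(OC)c3)n[nH]2)cc1` gives 98%
compound 3 `COc1cc(C(=O)/C=C/c2cc(-c3cc(OC)c(OC)c(OC)c3)n[nH]2)cc(OC)c1OC` gives 101%

These three compounds share one core and were tested in a functional assay on 786-0 cells (Homo sapiens) for cytotoxicity, read by sulforhodamine B assay, with a stated time of 48 h, tested at 0.01 uM; on this read-out higher numbers stand for a weaker effect at the one concentration tested and lower numbers for a stronger effect. Compound 2 sits among three numbers that all lie within the usual scatter of one another, so nothing yet separates them. Compound 4 `COc1cc(-c2cc(/C=C/C(=O)c3ccc(F)c(F)c3)[nH]n2)cc(OC)c1OC` differs from compound 2 by 3,4-difluorophenyl in place of 4-methoxyphenyl on a carbonyl carbon. For the measured compounds named here, one measured step bears on this change: exchanging a 3,4-dichlorophenyl for a 4-methoxyphenyl on the carbonyl carbon gave a number 3 percentage points higher from compound 1 to compound 2 (within the scatter). Since a ring carrying two halogens and a ring carrying one methoxy there gave numbers within the scatter, the move to 3,4-difluorophenyl is expected to give a number 1 percentage points lower from compound 2 to compound 4 (within the scatter). Compound 4 is therefore expected to show 97%, in the range 86% to 107%.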

Compound 4, a percentage reported as activity, at one concentration (the size of the read-out at that concentration, not a potency): 95%
The estimate for compound 4 lay 2 percentage points above the measured number, within the range that was stated.
By their numbers in this assay, from the lowest: compounds 1, 4, 2 and 3 (each within the scatter of the next).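

Placing 3,4-difluorophenyl on the carbonyl carbon gives a number 3 percentage points lower from compound 2 to compound 4 (within the scatter) and no change at the digits printed from compound 1 to compound 4 (within the scatter) in this assay, so neither swapping the methoxy ring for this ring nor swapping chlorine for fluorine on the dihalogenated ring separates the compounds. No measurement shown here explains this result. On these data alone, whether a ring carrying an amine or a carboxylic acid on this carbonyl carbon would shift the number beyond the scatter remains open. The compounds shown also leave open how this position behaves at any other concentration.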